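A few compounds are considered here, and "the series" means these few. Any claim that something is new, unique, unknown or untested is made for them only; others in the source may bear on it.

Measured so far:
compound 1 `Cc1cn(C)nc1Nc1cc2c(c(N)n1)c(C#N)c(N1CCC[C@H]1C)n2C` — 2110 nM
compound 2 `Cc1nn(CC(C)(C)O)cc1Nc1nc(N)c2c(C#N)c(N3CCC[C@H]3C)n(C)c2n1` — 49 nM

In an assay on isolated protein for inhibition of Leucine-rich repeat serine/threonine-protein kinase 2 (Homo sapiens), read by TR-FRET and LanthaScreen, with stated times of 50 min and 30 min, in the presence of a further agent that is not named here (a higher number here means a weaker inhibitor, a lower number a stronger inhibitor), compound 2 gives the lower of the two numbers, and compound 1 sits higher by a gap beyond the usual scatter. Compound 3 `Cc1nn(CC2(O)COC2)cc1Nc1nc(N)c2c(C#N)c(N3CCC[C@H]3C)n(C)c2n1` differs from compound 2 by 3-hydroxyoxetan-3-yl in place of 1-hydroxy-1-methylethyl on a saturated chain carbon bound to an aromatic nitrogen. Among the compounds with values here, no step of this kind has been measured, so the expectation rests on the structural change alone. For compound 3 the step of a 1.6-fold higher number from compound 2 to compound 3 (0.21 log units; within the scatter) is expected to be small, most likely within the scatter, with the number edging slightly upward. Compound 3 is therefore estimated at 80 nM, range 30 nM to 250 nM.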

Compound 3, half-maximal inhibitory concentration: 57 nM
The estimate for compound 3 lay 1.4-fold (0.15 log units) above the measured number, within the range that was stated.
By their numbers in this assay, from the lowest: compounds 2 and 3 (each within the scatter of the next); then compound 1.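

In this assay, putting 3-hydroxyoxetan-3-yl in place of 1-hydroxy-1-methylethyl gives a 1.2-fold higher number from compound 2 to compound 3 (0.07 log units; within the scatter), so this position tolerates the four-membered ring and its extra oxygen, and the assay does not separate the two groups. No data bear on why the two groups read alike.

Still open, on these data alone, is whether the hydroxy group is needed at all on this chain. Equally open, as far as these compounds go, is how an amine, a carboxylic acid or a longer chain would read in place of 2-hydroxy-2-methylpropyl.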